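Aryl ester in place of sulfonyl carbamate on the shared core

The compounds below may be only part of what the source reports. "The series", "measured", "known", "first", "only" and "open" are said of these compounds alone.

Working notes on the series. Compound 3 `CC1=CC[C@H]2[C@H](CC[C@]2(C)O)C(C)(C)[C@@H]1CC[C@H]1[C@]2(C)CC[C@H](OC(=O)NS(=O)(=O)c3ccc(C)cc3)C(C)(C)O[C@H]2CC[C@@]1(C)O` gives 47100 nM in a functional assay on MDA-MB-231 cells (Homo sapiens) for antiproliferative activity, read by MTT assay, with a stated time of 72 h (on this read-out lower numbers stand for stronger inhibition and higher numbers for weaker inhibition), the highest of the three numbers; compound 1 `CC(=O)O[C@H]1CC[C@]2(C)[C@H](CC[C@@](C)(O)[C@H]2CC[C@@H]2C(C)=CC[C@H]3[C@H](CC[C@]3(C)OC(C)=O)C2(C)C)OC1(C)C` gives 26200 nM, within the scatter of compound 3, and compound 2 `CC1=CC[C@H]2[C@@H]1CC=C(C)[C@@H](CC[C@H]1[C@]3(C)CC[C@H](OC(=O)c4ccc(Cl)cc4)C(C)(C)O[C@H]3CC[C@@]1(C)O)C2(C)C` gives 12700 nM, a lower number beyond the scatter. Compound 4 `CC1=CC[C@H]2[C@H](CC[C@]2(C)O)C(C)(C)[C@@H]1CC[C@H]1[C@]2(C)CC[C@H](OC(=O)c3ccccc3F)C(C)(C)O[C@H]2CC[C@@]1(C)O` is not yet measured. It differs from compound 3 in one place: 2-fluorophenyl in place of ((4-methylphenyl)sulfonyl)amino on a carbonyl carbon. Within the data shown here, no measured pair shows this change, so the step is guessed from the spread of the series alone. A modest move toward lower numbers is expected, since compound 2 gives 12700 nM and compound 3 stands highest. The expected step is a 2.4-fold lower number from compound 3 to compound 4 (0.37 log units; beyond the scatter). Compound 4 is estimated at 20000 nM, within 7000 nM to 55000 nM.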

Compound 4, half-maximal inhibitory concentration: 28700 nM
Beside the measured number, compound 4's estimate is 1.4-fold (0.16 log units) below it; the measured number falls inside the stated range.
By their numbers in this assay, from the lowest: compound 2; then compounds 1, 4 and 3 (each within the scatter of the next).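

In this assay, 2-fluorophenyl in place of ((4-methylphenyl)sulfonyl)amino on a carbonyl carbon gives a 1.6-fold lower number from compound 3 to compound 4 (0.22 log units; within the scatter). The group that leaves carries hydrogen-bond donors and acceptors and the group that enters carries neither, yet the read-out does not separate the two compounds at this position. No evidence on hand bears on the reason for this result.

Still open, on these data alone, is whether plain phenyl would read differently from 2-fluorophenyl on this carbonyl carbon. Also open, as far as these compounds go, is whether a simple amine or a longer alkyl chain there would move the number beyond the scatter.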